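The compounds below may be only part of what the source reports. "The series", "measured", "known", "first", "only" and "open" are said of these compounds alone.

Measured compounds and values in an ADME assay on microsomes from liver (Homo sapiens) for metabolic stability, with a stated time of 0.5 h, tested at 0.5 mg/mL; on this read-out higher numbers stand for a more stable compound and lower numbers for a less stable compound:

Compound 1, `CN(C)C(=O)CNC(=O)c1cc(-c2ccc(F)cc2)no1`, gives 84%.
Compound 2, `CN(C)C(=O)CCNC(=O)c1cc(-c2cccc(F)c2)no1`, is reported only as a limit of the assay, > 100%.
Compound 3, `CN(C)C(=O)CCNC(=O)c1cc(-c2ccccc2F)no1`, is likewise reported only as a limit, > 100%.

Compound 1 is thus the only one of the three with a plain number; the other two values sit at the limit of > 100% in this assay, at which 2 of the 3 values shown sit. Within the data shown here, the one step between measured compounds, a step that the two limits leave unreadable from compound 2 to compound 3, cannot be read in size, so it gives no usable guide.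

Compound 4 is `CC(CNC(=O)c1cc(-c2ccc(F)cc2)no1)C(=O)N(C)C`. It differs from compound 1 by 1-(dimethylcarbamoyl)ethyl in place of dimethylcarbamoyl on a saturated chain carbon bound to an amide-type nitrogen. Among the measured compounds shown here, none of the measured steps touches this part of the molecule, so no measured step bears on the change. With nothing pointing either way, the expected step from compound 1 to compound 4 in this assay is one within the scatter, no change at the digits printed from compound 1 to compound 4 (within the scatter). Compound 4 is therefore estimated at 84%, with a range from 65% to 100%.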

Compound 4, percent of the compound remaining: 61%
Compound 4: middle estimate off by 23 percentage points, on the high side, outside the stated range (below it).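

In this assay, putting 1-(dimethylcarbamoyl)ethyl in place of dimethylcarbamoyl on a saturated chain carbon bound to an amide-type nitrogen gives a number 23 percentage points lower from compound 1 to compound 4 (beyond the scatter). Among these compounds, this is the first step whose size can be read, the earlier one being hidden by two limits, and it shows that this part of the molecule is not a silent place in this assay: enlarging the group here goes with a real loss of stability. Nothing in the data at hand accounts for that loss.

One step cannot tell whether the extra carbons themselves matter or the way they are arranged, so a longer unbranched chain on the core of compound 1 remains an open case. Also open, from the compounds shown here alone, is how an amine or a carboxylic acid would fare in place of the dimethylcarbamoyl group.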